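The source may hold more compounds than are shown below. What is called first, only, known or untested is meant among the compounds shown, and "the series" means these compounds.

Measured in an assay on isolated protein for inhibition of 2-Hydroxyacid oxidase 2 (Homo sapiens), tested at 1 uM; a higher number here means a stronger effect of the compound at the concentration tested, a lower number a weaker effect:
compound 1, `Cc1n[nH]c(C(=O)O)c1Cc1cccc(-c2ccc(OC(F)(F)F)cc2)c1`: 6%
compound 2, `Cc1n[nH]c(C(=O)O)c1Cc1ccc(C(F)(F)F)cc1`: 9%
compound 3, `Cc1n[nH]c(C(=O)O)c1Cc1ccc(Oc2ccccc2)cc1`: 10%

On these numbers compound 1 sits at the low end, though its gaps to compound 2 and to compound 3 both lie within the usual scatter, so the three values are effectively alike and all small. Compound 4, `Cc1n[nH]c(C(=O)O)c1Cc1cccc(-c2ccc(C(N)=O)cc2)c1`, differs from compound 1 by carbamoyl in place of trifluoromethoxy on an aromatic carbon. Among the measured compounds shown here, the only measured step, a number 1 percentage points higher from compound 2 to compound 3 (within the scatter), swapped an unrelated pair of groups and was itself within the scatter, so it offers no direct guide to this change; all it shows is that such swaps on this core left the read-out low. Compound 4 is therefore expected to stay near compound 1, with a step of a number 2 percentage points higher from compound 1 to compound 4 (within the scatter) that is not expected to exceed the scatter. The estimate for compound 4 is 8%, ranging from 0% to 20%.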

Compound 4, a percentage reported as inhibition, at one concentration (the size of the read-out at that concentration, not a potency): 18%
Beside the measured number, compound 4's estimate is 10 percentage points below it; the measured number falls inside the stated range.
By their numbers in this assay, from the lowest: compounds 1, 2, 3 and 4 (each within the scatter of the next, the first and the last beyond it).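

In this assay, carbamoyl in place of trifluoromethoxy, para to a large group, gives a number 12 percentage points higher from compound 1 to compound 4 (beyond the scatter) and is the only step shown that clears the scatter. The group at this position can therefore shift the read-out, although compound 4 at 18% still shows only modest inhibition at the concentration tested. Nothing measured here explains the rise. From the compounds shown here alone, it remains open whether the gain is specific to carbamoyl, and an amine or a carboxylic acid at the same position would help to show this.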